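Methoxy added beside the carboxy group of compound 3

This account rests on a few compounds, and the source may have more. Where it says the series, first, only, none or still open, it means among the compounds named here.

Within the data shown here, the three compounds measured so far share one core and differ only in the aryl group on an oxygen on a saturated carbon. Compound 1 `Cc1c(OCCCCOc2ccccc2C(=O)O)ccc(C(=O)CC2CCCC2)c1O` carries a 2-carboxyphenyl there, and in an assay on HEK293 cells for positive allosteric modulation of metabotropic glutamate receptor 2 (Rattus norvegicus), read by thallium flux, with a stated time of 2.5 min (a lower number here means that less compound is needed, a higher number that more compound is needed for the effect), compound 1 gives 335 nM. Compound 2 `Cc1c(OCCCCOc2ccc(C(=O)O)cc2Cl)ccc(C(=O)CC2CCCC2)c1O` carries a 4-carboxy-2-chlorophenyl and gives 237 nM. Compound 3 `Cc1c(OCCCCOc2cccc(C(=O)O)c2)ccc(C(=O)CC2CCCC2)c1O` carries a 3-carboxyphenyl and gives 451 nM. All three values lie close together: there is a 1.4-fold lower number from compound 1 to compound 2 (0.15 log units; within the scatter), a 1.3-fold higher number from compound 1 to compound 3 (0.13 log units; within the scatter) and a 1.9-fold higher number from compound 2 to compound 3 (0.28 log units; within the scatter), so compound 3 cannot be told apart from either neighbour.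

Compound 4 `COc1ccc(C(=O)O)cc1OCCCCOc1ccc(C(=O)CC2CCCC2)c(O)c1C` differs from compound 3 by methoxy in place of hydrogen on an aromatic carbon, on an aromatic carbon of the six-membered aromatic ring, ortho to a large group and para to the carboxy group. Among the measured compounds shown here, no measured step adds a group to this ring in that way; the nearest comparison is the chloro of compound 2, whose step to compound 3 stayed within the scatter. Compound 4 is therefore expected to stay near compound 3, with a 1.1-fold lower number from compound 3 to compound 4 (0.03 log units; within the scatter), at an estimated 420 nM (range 150 nM to 1200 nM).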

Compound 4, half-maximal effective concentration: 425 nM
Compound 4: the middle estimate sits 1.0-fold (0.01 log units) below what was measured; the measured number falls inside the stated range.
By their numbers in this assay, from the lowest: compounds 2, 1, 4 and 3 (each within the scatter of the next).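

Methoxy in place of hydrogen on an aromatic carbon, ortho to a large group and para to a carboxy group, is the first change shown that adds a group to the 3-carboxyphenyl ring instead of exchanging one aryl group for another, and in this assay it gives a 1.1-fold lower number from compound 3 to compound 4 (0.03 log units; within the scatter) as its whole effect. The other two comparisons agree: a 1.8-fold higher number from compound 2 to compound 4 (0.25 log units; within the scatter) and a 1.3-fold higher number from compound 1 to compound 4 (0.10 log units; within the scatter) both leave compound 4 indistinguishable from its neighbours, so this position accepts the methoxy without a readable change in the number. Nothing at hand explains this result.

The compounds shown leave open whether an amine or a larger ether such as benzyloxy at this place would move the number beyond the scatter. They also leave open whether the methoxy would stay as silent with a tetrazole in place of the carboxylic acid or with a longer chain.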